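From carboxy to sulfomethyl on a short chain

This account rests on a few compounds, and the source may have more. Where it says the series, first, only, none or still open, it means among the compounds named here.

Measured so far in a functional assay on MDA-MB-468 cells (Homo sapiens) for cytotoxicity, read by resazurin assay, with a stated time of 72 h; on this read-out higher numbers stand for weaker inhibition and lower numbers for stronger inhibition
compound 1 `N#CCCSC(=S)NCc1cccnc1` gives 9530 nM
compound 2 `CC(=O)CCSC(=S)NCc1cccnc1` gives 4220 nM
compound 3 `O=C(O)CCSC(=S)NCc1cccnc1` gives 9320 nM

Compound 3 stands level with compound 1, as a 1.0-fold lower number from compound 1 to compound 3 (0.01 log units; within the scatter) shows, and both read higher than compound 2. The gap on that side is a 2.2-fold higher number from compound 2 to compound 3 (0.34 log units; beyond the scatter) and lies beyond the scatter.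

Compound 4 `O=S(=O)(O)CCCSC(=S)NCc1cccnc1` has not been measured yet. It differs from compound 3 in one place sulfomethyl in place of carboxy on a saturated chain carbon, two bonds along the chain from a sulfur with sulfomethyl in place of carboxy on a saturated chain carbon, two bonds along the chain from a sulfur.

Going by the values given here, no measured step makes this exact swap. The closest evidence comes from the other end-group changes at that place: a 2.3-fold lower number from compound 1 to compound 2 (0.35 log units; beyond the scatter) is modest, and a 1.0-fold lower number from compound 1 to compound 3 (0.01 log units; within the scatter) is within the scatter. Three compounds are thin evidence, but in this assay no step beyond the scatter is expected. The expected step is a 1.2-fold higher number from compound 3 to compound 4 (0.07 log units; within the scatter) and no larger. For compound 4 the estimate is 11000 nM (expected range 4500 nM to 30000 nM).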

Compound 4, half-maximal inhibitory concentration: 11100 nM
For compound 4 the middle estimate is 1.0-fold (0.00 log units) below the measured one; measured number inside the range.
By their numbers in this assay, from the lowest: compound 2; then compounds 3, 1 and 4 (each within the scatter of the next).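

In this assay, sulfomethyl in place of carboxy on a saturated chain carbon, two bonds along the chain from a sulfur, gives a step within the scatter (a 1.2-fold higher number from compound 3 to compound 4 (0.08 log units; within the scatter)), and the same holds for the swap from cyano (a 1.2-fold higher number from compound 1 to compound 4 (0.07 log units; within the scatter)). Cyano, carboxy and sulfomethyl thus read alike at this place despite their different heavy-atom counts, while acetyl stays apart, with a modest step beyond the scatter (a 2.6-fold higher number from compound 2 to compound 4 (0.42 log units; beyond the scatter)). Nothing available here explains why acetyl differs from the other three end groups.

On these data alone, whether an amine or an ester at this place would read with acetyl or with the other three remains open. The compounds shown also leave open whether a longer chain carrying a carboxylic acid would change the number.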